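The source may hold more compounds than are shown below. What is called first, only, known or untested is meant among the compounds shown, and "the series" means these compounds.

Measured so far in a functional assay on CWR22R cells (Homo sapiens) for antiproliferative activity, read by propidium iodide staining, with a stated time of 96 h; on this read-out higher numbers stand for weaker inhibition and lower numbers for stronger inhibition:

Compound 1 `CC(O)(COc1cccc(C(F)(F)F)c1)C(=O)Nc1cccc(S(F)(F)(F)(F)F)c1` gives 28900 nM.
Compound 2 `CC(O)(COc1cc(C(F)(F)F)cc(C(F)(F)F)c1)C(=O)Nc1cccc(S(F)(F)(F)(F)F)c1` gives 6500 nM.
Compound 3 `CC(O)(CS(=O)(=O)c1cccc(C(F)(F)F)c1)C(=O)Nc1ccc(S(F)(F)(F)(F)F)cc1` gives 23800 nM.

Compound 1 and compound 2 differ in one place: trifluoromethyl in place of hydrogen on an aromatic carbon. That change gave a 4.4-fold lower number from compound 1 to compound 2 (0.65 log units; beyond the scatter), a modest step toward stronger inhibition. Compound 3 shares no single counted difference with compound 1; the difference between the two cores is not broken down here. Their values are within the scatter of each other, so nothing separates them in this assay.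

Compound 4 `CC(O)(CS(=O)(=O)c1cc(C(F)(F)F)cc(C(F)(F)F)c1)C(=O)Nc1ccc(S(F)(F)(F)(F)F)cc1` has not yet been measured. It differs from compound 3 by trifluoromethyl in place of hydrogen on an aromatic carbon. The place of this change is described in the same words as for compound 1 and compound 2, so it is the same change on a different core.

For compound 4 the step from compound 3 is expected to be a 4.0-fold lower number from compound 3 to compound 4 (0.60 log units; beyond the scatter), close to the earlier one, because the same change gave a 4.4-fold lower number from compound 1 to compound 2 (0.65 log units; beyond the scatter). This expectation rests on a single example and on the closeness of compound 3 to compound 1, so it is held loosely. The estimate for compound 4 is 6000 nM, between 2500 nM and 15000 nM.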

Compound 4, half-maximal inhibitory concentration: 12700 nM
Estimate against measurement, compound 4: 2.1-fold (0.33 log units) below; low and high end bracket the measured number.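

In this assay, trifluoromethyl in place of hydrogen on an aromatic carbon gave a 1.9-fold lower number from compound 3 to compound 4 (0.27 log units; within the scatter), so on this core the step by itself cannot be told apart from the ordinary spread of repeated measurements. Set beside the same change on the other core, the two steps do not differ by more than that spread allows: the same change on two cores in this assay, a 4.4-fold lower number (0.65 log units; beyond the scatter) from compound 1 to compound 2 and a 1.9-fold lower number (0.27 log units; within the scatter) from compound 3 to compound 4, 2.4-fold (0.38 log units) apart, within the scatter of two such steps. Among these compounds, this shows no sign that the change behaves differently on the two cores, but it does not show that the effect carries over in full, as only one of the two steps stands clear of the scatter and two pairs of compounds are a very small sample.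

The compounds shown leave open what a chlorine atom, a nitrile or a methoxy group would give at the same aromatic carbon in place of trifluoromethyl. They also leave open whether an amine or a carboxylic acid at that place would fit the same picture on either core.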